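Lengthening the Side Chain of Compound 2

This account rests on a few compounds, and the source may have more. Where it says the series, first, only, none or still open, it means among the compounds named here.

For the measured compounds named here, in a physicochemical assay for lipophilicity, measured as octanol-water partition (on this read-out lower numbers stand for lower lipophilicity and higher numbers for higher lipophilicity), two compounds have numbers so far. Compound 1 `COC(=O)c1cn(C/C=C(/C)CC/C=C(\C)CCC=C(C)C)nn1` gives 5.25 and compound 2 `CCCc1cn(C/C=C(/C)CCC=C(C)C)nn1` gives 4.05 as the lower of the two, a gap beyond the usual scatter. These two compounds differ in more than one place, so that gap belongs to no single change.

Compound 3 `CCCc1cn(C/C=C(/C)CC/C=C(\C)CCC=C(C)C)nn1` is still unmeasured. It differs from compound 2 in one place, counted as 3-methylbut-2-en-1-yl in place of hydrogen on a saturated chain carbon bound to a double-bonded chain carbon and carrying 3-methylbut-2-en-1-yl in place of hydrogen on a saturated chain carbon bound to a double-bonded chain carbon. Going by the values given here, no measured pair shows this change alone, so its size has to be judged. Compound 3 shares its longer chain with compound 1, which reads 5.25 in this assay and carries a different group on the shared core. An upward step well beyond the scatter is expected, estimated as a number 1.65 log units higher from compound 2 to compound 3 (beyond the scatter) in this assay for this change. The expected value for compound 3 is 5.7 within a range from 5.2 to 6.3 for repeated measurements.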

Compound 3, partition coefficient: 6.5
Beside the measured number, compound 3's estimate is 0.80 log units below it, and the stated range ends below it.
By their numbers in this assay, from the lowest: compound 2; then compound 1; then compound 3.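

In this assay, 3-methylbut-2-en-1-yl in place of hydrogen on a saturated chain carbon bound to a double-bonded chain carbon gives a number 2.45 log units higher from compound 2 to compound 3 (beyond the scatter) as a large step, so this chain extension now has a measured size of its own rather than a judged one. With that longer chain held the same, propyl in place of methoxycarbonyl on an aromatic carbon gives a number 1.25 log units higher from compound 1 to compound 3 (beyond the scatter) as a second large step, which shows that the number depends strongly on the group on the shared core as well as on the chain. No supporting measurement bears on the reason for the size of either step.

Going by these compounds, each change is seen here only once, so it stays open whether 3-methylbut-2-en-1-yl would give a step of similar size on a compound carrying methoxycarbonyl on the shared core, or whether a further 3-methylbut-2-en-1-yl on the chain would add as much again. Also open, on these data alone, is where the number would fall with an amine or a carboxylic acid in place of propyl on the aromatic carbon.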